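Hydroxy for methoxy in a weakly active urea pair

A few compounds are considered here, and "the series" means these few. Any claim that something is new, unique, unknown or untested is made for them only; others in the source may bear on it.

Among the compounds with values here, compound 2 `COc1cc(-c2nn(-c3cccc(NC(=O)Nc4ccc(Cl)c(C(F)(F)F)c4)c3)cc2-c2ccncc2)ccc1Cl` is the only compound here with a numbered value in a functional assay on A549 cells (Homo sapiens) for inhibition, read by sulforhodamine B assay, with a stated time of 48 h (a lower number here means a stronger inhibitor of growth, a higher number a weaker inhibitor of growth), and compound 2 gives 16700 nM. Compound 1 `O=C(Nc1cccc(-n2cc(-c3ccncc3)c(-c3ccc(Cl)c(O)c3)n2)c1)Nc1ccc(Cl)c(Cl)c1` gives only a limit in this assay, > 32500 nM. That limit is the one noted as the limit of > 32500 nM in this assay, at which 1 of the 2 values shown sits. Compound 3 `O=C(Nc1cccc(-n2cc(-c3ccncc3)c(-c3ccc(Cl)c(O)c3)n2)c1)Nc1ccc(Cl)c(C(F)(F)F)c1` is compound 2 with hydrogen in place of methyl on an oxygen on an aromatic ring. Within the data shown here, no measured pair isolates this change, so the data give neither size nor direction for it. Compound 3 is therefore expected to stay near compound 2, with the step of a 1.2-fold higher number from compound 2 to compound 3 (0.08 log units; within the scatter) within the usual scatter. The estimate for compound 3 is 20000 nM, ranging from 8000 nM to 32500 nM.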

Compound 3, concentration for total growth inhibition: 5090 nM
Beside the measured number, compound 3's estimate is 3.9-fold (0.59 log units) above it; measured number outside the range, below it.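

In this assay, the change from methoxy to hydroxy on the 4-chloro-3-methoxyphenyl group now has a measured size and direction: a 3.3-fold lower number from compound 2 to compound 3 (0.52 log units; beyond the scatter). With the hydroxy kept, trifluoromethyl in place of chloro on an aromatic carbon gives an at least 6.3-fold lower number from compound 1 to compound 3 (0.80 log units; beyond the scatter). That second step rests on a limit of the assay for compound 1: the limit of > 32500 nM in this assay, at which 1 of the 3 values shown sits.

The compounds shown leave open whether the methoxy to hydroxy step holds with chloro in place of trifluoromethyl. They also leave open how an amine or an ethoxy group would read in place of the hydroxy.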